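The source may hold more compounds than are shown below. What is called first, only, known or untested is meant among the compounds shown, and "the series" means these compounds.

In a physicochemical assay for solubility, at pH 6.8 (a higher number here means a more soluble compound, a lower number a less soluble compound), three compounds sharing one core have been measured. Compound 1, `CCCN(Cc1ccc(OC(F)(F)F)cc1)[C@@H]1COc2nc([N+](=O)[O-])cn2C1`, gives only a limit of the assay, < 2 ug/mL. Among the compounds with values here, compound 2, `CN(Cc1ccc(OC(F)(F)F)cc1)[C@@H]1COc2nc([N+](=O)[O-])cn2C1`, gives 10 ug/mL, and the step of an at least 5.0-fold higher number from compound 1 to compound 2 (0.69 log units; beyond the scatter) is the single one-change step in this set. The limit for compound 1 is described by the limit of < 2 ug/mL in this assay, at which 1 of the 3 values shown sits. Compound 3, `O=[N+]([O-])c1cn2c(n1)OC[C@@H](NCc1ccc(OC(F)(F)F)cc1Cl)C2`, gives 30 ug/mL, the highest of the two numbers reported, with compound 2 nearest to it.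

Compound 4, `O=[N+]([O-])c1cn2c(n1)OC[C@@H](NCc1ccc(OC(F)(F)F)cc1OCC1CC1)C2`, differs from compound 3 in one place: cyclopropylmethoxy in place of chloro on an aromatic carbon. Within the data shown here, the only measured step concerns the group on the amine nitrogen, not the aromatic ring, so it does not bear directly on this change, and the expectation for compound 4 rests on the value of compound 3, 30 ug/mL, alone. A modest fall in this assay is expected, as the step of a 2.5-fold lower number from compound 3 to compound 4 (0.40 log units; beyond the scatter) indicates. Compound 4 is therefore estimated at 12 ug/mL, within a range from 4 ug/mL to 36 ug/mL.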

Compound 4, solubility: 6 ug/mL
Compound 4: middle estimate off by 2.0-fold (0.30 log units), on the high side; low and high end bracket the measured number.
By their numbers in this assay, from the lowest: compounds 4 and 2 (each within the scatter of the next); then compound 3. At a limit, below all of these: compound 1.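

In this assay, within the data shown here, this is the first measured change on the aromatic ring, as the earlier step concerned only the group on the amine nitrogen, and it shows that this aromatic carbon is not indifferent to what it carries: the step of a 5.0-fold lower number from compound 3 to compound 4 (0.70 log units; beyond the scatter) is modest but lies beyond the scatter. Exchanging a single chlorine for cyclopropylmethoxy, with its five heavy atoms, three-membered ring and hydrogen-bond acceptor, therefore goes with a lower number, not a higher one. No measurement shown here explains this step.

With only these two groups compared at this place, the parts of cyclopropylmethoxy cannot be told apart in their link to the step. On these data alone, how methoxy, an amine or a carboxylic acid on the same aromatic carbon would compare remains open.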